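Series notes: benzyl-ring halogens on the shared core

A few compounds are considered here, and "the series" means these few. Any claim that something is new, unique, unknown or untested is made for them only; others in the source may bear on it.

The three measured compounds share one core and differ only in the halogen pattern on the benzyl ring. Compound 1 `COc1cc(C(=O)Nc2ncc(Cc3cccc(C(F)(F)F)c3)s2)ccc1OCCO` carries a trifluoromethyl group there and gives 3 nM in an assay on microsomes for inhibition of acyl-CoA desaturase 1 (Mus musculus), with a stated time of 60 min; a higher number here means a weaker inhibitor, a lower number a stronger inhibitor. Compound 2 `COc1ccc(C(=O)Nc2ncc(Cc3cccc(F)c3)s2)cc1OCCO` carries a fluoro group and gives 2 nM. Compound 3 `COc1ccc(C(=O)Nc2ncc(Cc3cccc(Cl)c3)s2)cc1OCCO` carries a chloro group and gives 1 nM. Compound 3 thus sits at the low end of the three numbers; the gap to compound 2 lies within the scatter, while the gap to compound 1 lies beyond it. Among the compounds with values here, the single one-place step that is known, a 2.0-fold lower number from compound 2 to compound 3 (0.30 log units; within the scatter), is within the scatter.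

Compound 4 `COc1ccc(C(=O)Nc2ncc(Cc3cc(F)cc(F)c3)s2)cc1OCCO` is not yet measured. It differs from compound 3 by 3,5-difluorophenyl in place of 3-chlorophenyl on a saturated chain carbon bound to an aromatic carbon. Within the data shown here, the only step that bears on this is the halogen swap from compound 2 to compound 3, which was within the scatter; no measured pair shows the effect of a second fluoro group on that ring. On this basis no step beyond the scatter is expected in this assay in either direction, and the estimated step from compound 3 to compound 4 is a 2.0-fold higher number from compound 3 to compound 4 (0.30 log units; within the scatter). Compound 4 is therefore expected to give about 2 nM, with a range from 0.7 nM to 6 nM.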

Compound 4, half-maximal inhibitory concentration: 0.1 nM
Estimate against measurement, compound 4: 20-fold (1.30 log units) above; measured number outside the range, below it.
By their numbers in this assay, from the lowest: compound 4; then compounds 3, 2 and 1 (each within the scatter of the next, the first and the last beyond it).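

Working notes on the benzyl ring: the earlier halogen swap, a 2.0-fold lower number from compound 2 to compound 3 (0.30 log units; within the scatter), gave no evidence that this ring could move the number in this assay beyond the scatter, but the new steps show that it can. Fluoro in place of hydrogen on an aromatic carbon gives a 20-fold lower number from compound 2 to compound 4 (1.30 log units; beyond the scatter), so this single change on the ring carries a large effect, and the change from 3-chlorophenyl to 3,5-difluorophenyl on a saturated chain carbon bound to an aromatic carbon gives a 10-fold lower number from compound 3 to compound 4 (1.00 log units; beyond the scatter). No measurement at hand accounts for the size of these steps.

Open, going by these compounds, is whether the low number in compound 4 depends on having two fluoro groups specifically, or whether a chloro group in place of either fluoro group would keep it. Also open is how this ring responds to groups of another kind in place of a fluoro group, such as a nitrile, a methoxy group or an amine, since only halogen-bearing rings appear in the compounds shown.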